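The source may hold more compounds than are shown below. What is called first, only, known or untested is meant among the compounds shown, and "the series" means these compounds.

The shared core of compound 1 `COc1cc(-c2ccnc3cc(-c4ccc5ccn(C)c5c4)nn23)cc(OC)c1OC` carries a 1-methyl-1H-indol-6-yl group, and in a functional assay on B16-F0 cells (Mus musculus) for inhibition, read by CCK-8 assay, with a stated time of 48 h (on this read-out lower numbers stand for stronger inhibition and higher numbers for weaker inhibition), compound 1 gives 657 nM. Compound 2 `COc1cc(-c2ccnc3cc(-c4ccccc4)nn23)cc(OC)c1OC` bears a plain phenyl at the same place and gives 4730 nM, while compound 3 `COc1cc(-c2ccnc3cc(-c4ccc(N(C)C)cc4)nn23)cc(OC)c1OC` carries 4-(dimethylamino)phenyl and gives 702 nM. Among these three numbers compound 3 stands second highest: its nearest neighbour is compound 1, a difference that lies within the scatter, and its furthest is compound 2, well beyond it, as the step of a 6.7-fold lower number from compound 2 to compound 3 (0.83 log units; beyond the scatter) shows. Compound 4 `COc1cc(-c2ccnc3cc(-c4ccc5c(ccn5C)c4)nn23)cc(OC)c1OC` differs from compound 3 in one place: 1-methyl-1H-indol-5-yl in place of 4-(dimethylamino)phenyl on an aromatic carbon. Within the data shown here, two measured steps bear on this change. The step of a 1.1-fold higher number from compound 1 to compound 3 (0.03 log units; within the scatter) shows that a 1-methyl-1H-indol-6-yl group and a 4-(dimethylamino)phenyl group give numbers within the scatter of each other, whereas a 7.2-fold higher number from compound 1 to compound 2 (0.86 log units; beyond the scatter) shows that removing such a substituted aryl altogether costs much more. Since the entering 1-methyl-1H-indol-5-yl is the same substituted bicyclic group as in compound 1, differing only in its attachment, compound 4 is expected to show a step of a 1.1-fold lower number from compound 3 to compound 4 (0.03 log units; within the scatter) that remains within the scatter. Compound 4 is therefore estimated at 650 nM, with a range from 280 nM to 1500 nM.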

Compound 4, half-maximal inhibitory concentration: 48 nM
Compound 4: middle estimate off by 14-fold (1.13 log units), on the high side; measured number outside the range, below it.
By their numbers in this assay, from the lowest: compound 4; then compounds 1 and 3 (each within the scatter of the next); then compound 2.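

In this assay, the attachment point of the bicyclic group matters far more than the earlier compounds suggested: 1-methyl-1H-indol-5-yl and 1-methyl-1H-indol-6-yl are not interchangeable on this aromatic carbon, as shown by (a 14-fold lower number from compound 1 to compound 4 (1.14 log units; beyond the scatter)). The 1-methyl-1H-indol-5-yl group also stands well apart from 4-(dimethylamino)phenyl (a 15-fold lower number from compound 3 to compound 4 (1.17 log units; beyond the scatter)) and from plain phenyl (a 99-fold lower number from compound 2 to compound 4 (1.99 log units; beyond the scatter)), so the close match between compound 1 and compound 3 does not extend to compound 4. No measurement at hand explains why this one change in attachment has so large an effect.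

The compounds shown leave open whether the low number of compound 4 depends on the methyl on the ring nitrogen, which an unmethylated 1H-indol-5-yl group would test. They also leave open whether a benzofuran-5-yl group, with oxygen in place of that nitrogen, would give a similar number.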